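The source may report more compounds than this note shows. Statements on the series, on what has been measured and on what is new or still open speak of the compounds shown alone.

Compound 1 `CN1Cc2ccc(OCc3ccc(-c4ccccc4)cc3)cc2[C@@H](O)C1`: 23000 nM
Compound 2 `CN1Cc2ccc(OCc3ccc([N+](=O)[O-])cc3)cc2[C@@H](O)C1`: > 50000 nM, a limit of the assay
Compound 3 `COc1ccc(COc2ccc3c(c2)[C@@H](O)CN(C)C3)cc1`: > 50000 nM, a limit of the assay

In an ADME assay on Vero cells (Chlorocebus sabaeus) for cytotoxicity, read by sulforhodamine B assay, with a stated time of 72 h (on this read-out higher numbers stand for weaker inhibition and lower numbers for stronger inhibition), compound 1 alone gives a number. For compound 3 only a limit is reached, the same limit at which a second value sits (the limit of > 50000 nM in this assay, at which 2 of the 3 values shown sit). Compound 4 `CN1Cc2ccc(OCc3ccc(Oc4ccc(F)cc4)cc3)cc2[C@@H](O)C1` differs from compound 3 by 4-fluorophenyl in place of methyl on an oxygen on an aromatic ring. Among the measured compounds shown here, the one measured step that bears on this runs the opposite way: an at least 2.1-fold higher number from compound 1 to compound 3 (0.33 log units; beyond the scatter), so swapping an aromatic ring for methoxy pushed the number up at least modestly, and restoring an aromatic ring is expected to pull it back down, toward where compound 1 stands. Compound 4 is therefore expected near 30000 nM, within 12000 nM to 60000 nM. The expected change is an at least 1.6-fold lower number from compound 3 to compound 4 (0.22 log units; that floor lies within the scatter).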

Compound 4, half-maximal inhibitory concentration: 5600 nM
Compound 4: middle estimate off by 5.4-fold (0.73 log units), on the high side, and the stated range ends above it.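

In this assay, among the compounds shown here, the earlier compounds showed that an aromatic ring at this place gave a lower number than methoxy or nitro, and 4-fluorophenoxy now goes further than phenyl, with a 4.1-fold lower number from compound 1 to compound 4 (0.61 log units; beyond the scatter). Against the two smaller groups the steps are an at least 8.9-fold lower number from compound 3 to compound 4 (0.95 log units; beyond the scatter) and an at least 8.9-fold lower number from compound 2 to compound 4 (0.95 log units; beyond the scatter). Those two steps are only floors, because compound 2 and compound 3 each stand at a limit of the assay: the limit of > 50000 nM in this assay, at which 2 of the 4 values shown sit.

Which part of 4-fluorophenoxy carries the change, the oxygen link or the fluorine, stays open. Going by these compounds, a plain phenoxy group would separate the two, and how an amine or a carboxylic acid would read at this place is also open.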